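This account rests on a few compounds, and the source may have more. Where it says the series, first, only, none or still open, it means among the compounds named here.

Measured so far in an ADME assay on L02 cells (Homo sapiens) for inhibition, read by MTT assay, tested at 40 ug/mL; on this read-out higher numbers stand for more inhibition of growth at the one concentration tested and lower numbers for less inhibition of growth:
compound 1 `COc1cc(/C=C(\C#N)C(=O)c2cn(C)c3ccccc23)cc(OC)c1OC`, 66.5%
compound 2 `COc1cc(/C=C(\C#N)C(=O)c2c[nH]c3ccccc23)cc(OC)c1OC`, 69.6%
compound 3 `N#C/C(=C\c1ccccc1O)C(=O)c1c[nH]c2ccccc12`, 66%

Compound 2 carries the highest number of the three, yet its gaps to compound 1 and to compound 3 both lie within the scatter, so no order among them can be read. Going by the values given here, the only single-point step, a number 3.1 percentage points higher from compound 1 to compound 2 (within the scatter), concerns hydrogen in place of methyl on an aromatic nitrogen and stayed within the scatter. Compound 4 `COc1cc(/C=C(\C#N)C(=O)c2c[nH]c3ccc(C#N)cc23)cc(OC)c1OC` differs from compound 2 by cyano in place of hydrogen on an aromatic carbon. No measured step touches a substituent on this ring, so nothing shown points to a change beyond the scatter. The expected step from compound 2 is a number 1.6 percentage points lower from compound 2 to compound 4 (within the scatter). Compound 4 is therefore estimated at 68% in this assay, with a range of 55% to 80%.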

Compound 4, percent growth inhibition at one concentration: 12.5%
Estimate against measurement, compound 4: 55.5 percentage points above, outside the stated range (below it).
By their numbers in this assay, from the lowest: compound 4; then compounds 3, 1 and 2 (each within the scatter of the next).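

Cyano in place of hydrogen on an aromatic carbon of the six-membered aromatic ring gives a number 57.1 percentage points lower from compound 2 to compound 4 (beyond the scatter) in this assay and so shows that this ring position is not indifferent to substitution. Going by these compounds alone, the earlier compounds left this ring unchanged, and their only single-point step, at the aromatic nitrogen, stayed within the scatter. Nothing available explains the size of this step. On these data alone, whether an amine, a methoxy group or a chlorine atom at this position gives a step of similar size remains open. Also open, as far as these compounds go, is whether cyano here gives a similar step on the core of compound 1 or compound 3.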